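The source may hold more compounds than are shown below. What is called first, only, known or untested is meant among the compounds shown, and "the series" means these compounds.

In a functional assay on HeLa cells (Homo sapiens) for inhibition, read by MTT assay, with a stated time of 72 h (a lower number here means a stronger inhibitor, a higher number a weaker inhibitor), compound 1 `COc1cccc(/C=C/C(=O)Nc2cc(OC)c(OC)c(OC)c2)c1` gives 16500 nM while compound 2 `C=C(Br)C(=O)Nc1cccc(/C=C/C(=O)Nc2cccc3ccccc23)c1` gives 1400 nM and compound 3 `C=C(Br)C(=O)Nc1cccc(/C=C/C(=O)Nc2ccc(F)c(F)c2)c1` gives 1900 nM on the same read-out. Compound 3 cannot be told apart from compound 2 on these numbers, since the two lie within the usual scatter. Its number does sit well below that of compound 1, beyond the scatter, which makes it the stronger inhibitor of that pair.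

For the measured compounds named here, compound 4 `C=C(Br)C(=O)Nc1cccc(/C=C/C(=O)Nc2ccc(OC)cc2)c1` keeps the core of compound 3 but carries 4-methoxyphenyl in place of 3,4-difluorophenyl on an amide-type nitrogen as its single change. Going by the values given here, no measured pair shows this exact swap. Among the compounds with values here, the only hint comes from compound 3 at 1900 nM and compound 2 at 1400 nM which differ in the group on that same nitrogen and still sit within the scatter. No step beyond the scatter is therefore expected in this assay and the estimated step of a 1.2-fold lower number from compound 3 to compound 4 (0.07 log units; within the scatter) has no firm direction. For compound 4 the estimate is 1600 nM with an expected range from 600 nM to 4500 nM in this test.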

Compound 4, half-maximal inhibitory concentration: 790 nM
The estimate for compound 4 lay 2.0-fold (0.31 log units) above the measured number, within the range that was stated.
By their numbers in this assay, from the lowest: compounds 4, 2 and 3 (each within the scatter of the next, the first and the last beyond it); then compound 1.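

In this assay, the group on the amide-type nitrogen can shift the number beyond the scatter: swapping 3,4-difluorophenyl for 4-methoxyphenyl gives a 2.4-fold lower number from compound 3 to compound 4 (0.38 log units; beyond the scatter), a modest step but the first measured at this position. The two groups have the same count of heavy atoms and the same six-membered aromatic ring of carbon only, so the step comes with a change in what the ring carries, not in the ring itself. No measurement here explains the step.

A single swap cannot separate the gain of the methoxy group from the loss of the fluorine atoms. On these data alone, how a plain phenyl, 4-fluorophenyl or 4-hydroxyphenyl on that nitrogen would compare remains open.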